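The source may report more compounds than this note shows. Statements on the series, on what has been measured and on what is new or still open speak of the compounds shown alone.

Measured in a functional assay on HL-60 cells (Homo sapiens) for antiproliferative activity, read by MTT assay, with a stated time of 72 h; on this read-out lower numbers stand for stronger inhibition and higher numbers for weaker inhibition:
compound 1, `NC1=NC2(CCOCC2)N(OCCCOc2ccc(Cl)cc2)C(N)=N1`, gives 330 nM
compound 2, `NC1=NC2(CCOCC2)N(OCCCOc2cccc(Br)c2)C(N)=N1`, gives 560 nM
compound 3, `NC1=NC2(CCSCC2)N(OCCCOc2cccc(Br)c2)C(N)=N1`, gives 200 nM

Compound 1 and compound 2 share a core and differ only in the aryl group on the ether oxygen: 4-chlorophenyl in place of 3-bromophenyl on an oxygen on a saturated carbon. This change gave a 1.7-fold lower number from compound 2 to compound 1 (0.23 log units; within the scatter), a step within the scatter, so the two values are read as equivalent. Compound 2 and compound 3 carry different cores; that difference is not broken down here. Compound 3 has the lowest number of the three measured, its gap to compound 1 lying within the scatter and its gap to compound 2 beyond it.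

Compound 4, `NC1=NC2(CCSCC2)N(OCCCOc2ccc(Cl)cc2)C(N)=N1`, is not yet measured in this assay. It differs from compound 3 by 4-chlorophenyl in place of 3-bromophenyl on an oxygen on a saturated carbon, the same change as from compound 2 to compound 1, now made on the core of compound 3, at the same place. Among the compounds with values here, on the one precedent, a 1.7-fold lower number from compound 2 to compound 1 (0.23 log units; within the scatter), the expected step is of similar size: a 1.5-fold lower number from compound 3 to compound 4 (0.19 log units; within the scatter), an expectation that rests on compound 3 at 200 nM and on that earlier step. Compound 4 is therefore estimated at 130 nM, with a range expected from 60 nM to 300 nM.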

Compound 4, half-maximal inhibitory concentration: 430 nM
Estimate against measurement, compound 4: 3.3-fold (0.52 log units) below; the whole stated range lies below it.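

On the core of compound 3, 4-chlorophenyl in place of 3-bromophenyl gives a 2.2-fold higher number from compound 3 to compound 4 (0.33 log units; beyond the scatter) in this assay. Set beside the earlier step, this change does not carry from one core to the other as a fixed increment: the same change on two cores in this assay, a 1.7-fold lower number (0.23 log units; within the scatter) from compound 2 to compound 1 and a 2.2-fold higher number (0.33 log units; beyond the scatter) from compound 3 to compound 4, 3.6-fold (0.56 log units) apart, beyond the scatter of two such steps This rests on a single pair of steps among four compounds, so it shows that the result of this change differs between these two cores in this assay, but it does not show why they differ or predict the result on any further core.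

The change replaces bromine with chlorine and alters the halogen's place on the ring in one move, so the compounds shown leave open which of the two accounts for the different steps. Also open, going by these compounds, is how the two cores compare when an unsubstituted phenyl group replaces the halogenated aryl groups, or when a longer chain replaces the present saturated chain.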